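Inverting Both Stereocentres of Compound 2

The source may report more compounds than this note shows. Statements on the series, on what has been measured and on what is new or still open speak of the compounds shown alone.

In a functional assay on QGY cells (Homo sapiens) for cytotoxicity, read by MTT assay, with a stated time of 48 h (on this read-out higher numbers stand for weaker inhibition and lower numbers for stronger inhibition), compound 1 `COc1cc([C@@H]2C[C@]2(CO)C(=O)NCc2ccc(C)cc2)cc(OC)c1OC` gives 25100 nM, while compound 2 `COc1cc([C@H]2C[C@]2(CO)C(=O)NCc2ccc(C)cc2)cc(OC)c1OC` gives 56100 nM. Compound 2 therefore has the higher number of the two and is the weaker inhibitor. Compound 3 `COc1cc([C@@H]2C[C@@]2(CO)C(=O)NCc2ccc(C)cc2)cc(OC)c1OC` is the mirror image of compound 2: the two compounds have the same atoms and bonds and differ only in configuration as drawn: 2 of 2 stereo elements differ (all stereocentres are inverted: mirror images); a stereocentre at a saturated ring carbon is drawn R in compound 2 and S in compound 3; a stereocentre at a saturated ring carbon is drawn S in compound 2 and R in compound 3. Within the data shown here, one measured step bears on this change. It is a 2.2-fold higher number from compound 1 to compound 2 (0.35 log units; beyond the scatter), a modest shift that arose when only one of the two stereocentres was drawn differently, as the fact that compounds 1 and 2 differ only in the configuration as drawn shows. Among the measured compounds shown here, no measured step yet inverts both stereocentres at once, so the expectation is loose. A step of similarly modest size is expected in this assay, leaning towards a lower number because compound 2 stands at 56100 nM, the higher of the two values. The expected change is a 1.9-fold lower number from compound 2 to compound 3 (0.27 log units; within the scatter). For compound 3, the estimated value is 30000 nM, with an expected range of 11000 nM to 80000 nM.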

Compound 3, half-maximal inhibitory concentration: 58700 nM
Estimate against measurement, compound 3: 2.0-fold (0.29 log units) below; the range from low to high includes it.
By their numbers in this assay, from the lowest: compound 1; then compounds 2 and 3 (each within the scatter of the next).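

The mirror-image pair reads alike in this assay (a 1.0-fold higher number from compound 2 to compound 3 (0.02 log units; within the scatter)), so this assay does not separate these two forms. Inverting the other stereocentre of compound 1 also gives a modest step beyond the scatter (a 2.3-fold higher number from compound 1 to compound 3 (0.37 log units; beyond the scatter)), just as the inversion already seen did. Compound 1 therefore stands apart as the strongest of the three, and a single inversion at either stereocentre leads to compounds that lie within the scatter of each other.

As far as these compounds go, how the mirror image of compound 1 would read remains open, so the full set of stereo forms cannot yet be compared. From the compounds shown here alone, it is also open whether the same small preference for compound 1 would hold if a carboxylic acid or an amine stood in place of the hydroxymethyl group.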